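Triazole aryl substituent change in a cinnamic acid series

The source may hold more compounds than are shown below. What is called first, only, known or untested is meant among the compounds shown, and "the series" means these compounds.

Measured compounds:
- compound 1, `COc1ccc(/C=C\C(=O)O)c(OCc2cn(-c3ccc(CO)cc3)nn2)c1CC=C(C)C`: 19300 nM
- compound 3, `COc1ccc(/C=C\C(=O)O)c(OCc2cn(-c3ccc(C#N)cc3)nn2)c1CC=C(C)C`: 32000 nM
- compound 2, `COc1ccc(/C=C\C(=O)O)c(OCc2cn(-c3ccccc3I)nn2)c1CC=C(C)C`: "not determined" (no result reported)

All three share one core; they differ only in the aryl group on the triazole nitrogen. In a functional assay on COLO 205 cells (Homo sapiens) for cytotoxicity, read by MTT assay, with a stated time of 24 h (on this read-out higher numbers stand for weaker inhibition and lower numbers for stronger inhibition), compound 1 gives 19300 nM, and in this assay compound 3 gives 32000 nM. Compound 3 carries the highest of the two numbers, but the step of a 1.7-fold higher number from compound 1 to compound 3 (0.22 log units; within the scatter) is within the scatter, so the two values cannot be ordered. Compound 2, with an ortho-iodophenyl on the triazole, has in this assay only "not determined" (no result reported).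

The next compound is compound 4, `COc1ccc(/C=C\C(=O)O)c(OCc2cn(-c3cccc([N+](=O)[O-])c3)nn2)c1CC=C(C)C`. Relative to compound 3 the change is 3-nitrophenyl in place of 4-cyanophenyl on an aromatic nitrogen. For the measured compounds named here, only one measured step, the one from compound 1 to compound 3, bears on aryl substitution at this position, and it was within the scatter. Going by the values given here, no step speaks to a nitro group or to the new ring position, so the expectation rests on that single small step: no change beyond the scatter is expected, a 1.1-fold lower number from compound 3 to compound 4 (0.06 log units; within the scatter). For compound 4 the estimated value in this assay is 28000 nM, with an expected range from 12000 nM to 65000 nM.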

Compound 4, half-maximal inhibitory concentration: 6900 nM
Compound 4: middle estimate off by 4.1-fold (0.61 log units), on the high side; measured number outside the range, below it.
By their numbers in this assay, from the lowest: compound 4; then compounds 1 and 3 (each within the scatter of the next).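

In this assay, for the compounds shown here, the aryl group on the aromatic nitrogen can shift the number beyond the scatter: there is a 4.6-fold lower number from compound 3 to compound 4 (0.67 log units; beyond the scatter) and a 2.8-fold lower number from compound 1 to compound 4 (0.45 log units; beyond the scatter) in this series, whereas the one earlier step at this position stayed within the scatter. Compound 4 is therefore set apart from both other measured compounds, but 3-nitrophenyl differs from 4-cyanophenyl in both the substituent and where it sits on the ring, so the two changes cannot be separated. No data are at hand to explain the shift.

Open, going by these compounds, is whether 4-nitrophenyl or 3-cyanophenyl would track the substituent or its place on the ring, and whether an amine or a carboxylic acid on the aryl ring would move the number further. Going by these compounds alone, compound 2 has no number, so no step to it can be read.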